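Chain variation at the amine of the shared core

The source may hold more compounds than are shown below. What is called first, only, known or untested is meant among the compounds shown, and "the series" means these compounds.

Two members of the series have been run in a functional assay on the whole organism (strain ddY) with Mus musculus as the target, in the formalin test, at a dose of 100 mg/kg by the oral route; on this read-out lower numbers stand for less inhibition and higher numbers for more inhibition at the one dose given (going by the name of the read-out). Compound 1 `CC[C@H](O)CNCC(=O)N1CCc2ccccc2C1C1CCCCC1` gives 27%. Compound 2 `C[C@@H](O)CNCC(=O)N1CCc2ccccc2C1C1CCCCC1` gives 39%. For the measured compounds named here, the one measured step, a number 12 percentage points higher from compound 1 to compound 2 (beyond the scatter), is 1-hydroxyethyl in place of 1-hydroxypropyl on a saturated chain carbon bound to an amine nitrogen; a shorter chain therefore went with a higher number. On these two numbers compound 2 stands highest, with compound 1 the nearest and beyond the scatter below it.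

Compound 3 `CC(C)C[C@@H](CO)NCC(=O)N1CCc2ccccc2C1C1CCCCC1` is not yet measured. It differs from compound 2 by 1-(hydroxymethyl)-3-methylbutyl in place of 2-hydroxypropyl on an amine nitrogen. Going by the values given here, the measured step bears on this only loosely: it shows that chain size at the amine moves the read-out, but the change to compound 3 enlarges the group and also shifts where the hydroxyl sits, which no measured pair covers. Taking the step from compound 1 to compound 2 as the only guide, a larger chain is expected to give a lower number, so the estimated step is a number 9 percentage points lower from compound 2 to compound 3 (within the scatter), modest and likely near the edge of the scatter. Compound 3 is therefore expected to give 30%, within the range 14% to 48%.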

Compound 3, a percentage reported as inhibition, in the whole organism at one dose (the size of the read-out at that dose, not a potency): 32%
Estimate against measurement, compound 3: 2 percentage points below; low and high end bracket the measured number.
By their numbers in this assay, from the lowest: compounds 1, 3 and 2 (each within the scatter of the next, the first and the last beyond it).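

Moving to the larger 1-(hydroxymethyl)-3-methylbutyl group on the amine nitrogen in this assay gives a number 7 percentage points lower from compound 2 to compound 3 (within the scatter) and, against the 2-hydroxybutyl compound, a number 5 percentage points higher from compound 1 to compound 3 (within the scatter) so compound 3 cannot be separated from either neighbour, although compound 1 and compound 2 are separated from each other. The link between a larger group and a lower number, suggested by compound 1 and compound 2 alone, therefore does not extend to compound 3, which carries the largest group here and goes against that reading; this position accepts the group with 7 heavy atoms without a step beyond the scatter from either earlier compound. Nothing available on these compounds gives a reason for these numbers.

On these data alone, the change to compound 3 alters the size of the group and the place of the hydroxyl together, so the share of each in the result stays open. Also open, as far as these compounds go, is how this assay responds when the hydroxyl gives way to a methoxy group or a carboxylic acid, or when a longer unbranched chain carries the hydroxyl at the end.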